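A few compounds are considered here, and "the series" means these few. Any claim that something is new, unique, unknown or untested is made for them only; others in the source may bear on it.

Measured so far in a functional assay on K562 cells (Homo sapiens) for inhibition, read by trypan blue exclusion, with a stated time of 72 h; on this read-out higher numbers stand for weaker inhibition and lower numbers for stronger inhibition:
Compound 1 `Cn1c(=O)c(S(=O)(=O)c2ccc(F)cc2F)cc2cnc(Nc3ccc4[nH]c(C(=O)O)cc4c3)nc21` gives 10000 nM
Compound 2 `Cn1c(=O)c(S(=O)(=O)c2ccc(F)cc2F)cc2cnc(Nc3cccc4[nH]ccc34)nc21` gives 1500 nM
Compound 3 `Cn1c(=O)c(S(=O)(=O)c2ccccc2)cc2cnc(Nc3ccc4cc[nH]c4c3)nc21` gives 10000 nM

Compound 3 stands level with compound 1 at the digits shown, and the two share the highest number of the three, while compound 2 sits lower. Compound 4 `Cn1c(=O)c(S(=O)(=O)c2ccc(F)cc2F)cc2cnc(Nc3ccc4cc[nH]c4c3)nc21` departs from compound 3 in one place: 2,4-difluorophenyl in place of phenyl on a sulfonyl sulfur.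

For the measured compounds named here, no measured step covers this change. The only one, a 6.7-fold lower number from compound 1 to compound 2 (0.82 log units; beyond the scatter), lies elsewhere on the molecule and keeps the 2,4-difluorophenyl on both sides. Both compound 1 and compound 2 carry that group, yet compound 2 reaches 1500 nM while compound 1 stays at 10000 nM, so the group alone settles little. Compound 4 keeps the amine group of compound 3 and gains the sulfonyl group of compound 2, so a modest move to a lower number is expected, with no move beyond the scatter still possible. The expected change is a 2.9-fold lower number from compound 3 to compound 4 (0.46 log units; beyond the scatter) in this assay by this estimate. For compound 4 the estimate is 3500 nM, with an expected range from 700 nM to 10000 nM as the outcome.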

Compound 4, half-maximal inhibitory concentration: 5000 nM
The estimate for compound 4 lay 1.4-fold (0.15 log units) below the measured number; measured number inside the range.
By their numbers in this assay, from the lowest: compound 2; then compounds 4, 1 and 3 (each within the scatter of the next).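

In this assay, for the compounds shown here, 2,4-difluorophenyl in place of phenyl on the sulfonyl sulfur gives a 2.0-fold lower number from compound 3 to compound 4 (0.30 log units; within the scatter) and so does not separate the pair, which the earlier compounds could not show. With the 2,4-difluorophenyl held fixed, 1H-indol-6-yl in place of 1H-indol-4-yl on the nitrogen gives a 3.3-fold higher number from compound 2 to compound 4 (0.52 log units; beyond the scatter) and lies beyond the scatter, so the attachment point on the indole matters here more than the sulfonyl change does. By contrast, 1H-indol-6-yl in place of 2-carboxy-1H-indol-5-yl gives a 2.0-fold lower number from compound 1 to compound 4 (0.30 log units; within the scatter) and stays within the scatter, and nothing available accounts for any of these steps.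

The compounds shown leave open whether phenyl and 2,4-difluorophenyl would also stand level when 1H-indol-4-yl sits on the nitrogen. Going by these compounds, how a methyl group or a single fluorine on that sulfonyl phenyl would read also remains open.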